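This account rests on a few compounds, and the source may have more. Where it says the series, first, only, none or still open, it means among the compounds named here.

Compound 1, `CCCC/C=C\CCCCCCCCCc1cc(=O)c2c(O)cc(OCOC)cc2o1`, in a functional assay on MCF7 cells (Homo sapiens) for antiproliferative activity, read by MTT assay; on this read-out higher numbers stand for weaker inhibition and lower numbers for stronger inhibition: > 67200 nM
Compound 2, `CCCCCCCCCCCCCCCc1cc(=O)c2c(O)c(C)c(O)c(C)c2o1`, in this assay: > 67200 nM
Compound 3, `CCCC/C=C\CCCCCCCCCc1cc(=O)c2c(O)cc(OCOC)c(C)c2o1`, in this assay: > 67200 nM

The value of compound 1 is a limit of the assay and not a number. The value of compound 2 is also a limit. The value of compound 3 is likewise a limit. The change from compound 3 to compound 1 is hydrogen in place of methyl on an aromatic carbon; it gives a step that the two limits leave unreadable from compound 3 to compound 1, because of the limit of > 67200 nM in this assay, at which 3 of the 3 values shown sit.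

Compound 4, `CCCCCCCCCCCCCCCc1cc(=O)c2c(O)cc(O)c(C)c2o1`, is not yet measured. It differs from compound 2 by hydrogen in place of methyl on an aromatic carbon. Going by the values given here, this is the same kind of change as the one from compound 3 to compound 1, but its surroundings differ: there the place was ortho to a fused ring, ortho to a methoxymethoxy group, meta to a fused ring and para to a hydroxy group, here it is ortho to two hydroxy groups, meta to a fused ring, meta to a methyl group and para to a fused ring. The difference between the two cores is not broken down here.

Since compound 2 gives only the limit > 67200 nM and (the limit of > 67200 nM in this assay, at which 3 of the 3 values shown sit), the step from compound 2 to compound 4 is expected to be a step that the limit leaves unreadable from compound 2 to compound 4, with no readable change in sight. Compound 4 is therefore estimated at 100000 nM, most likely again a limit rather than a number.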

Compound 4, half-maximal inhibitory concentration: 17500 nM
Compound 4: the middle estimate sits 5.7-fold (0.76 log units) above what was measured; measured number below the stated range.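

On the core of compound 2, hydrogen in place of methyl on an aromatic carbon gives, in this assay, an at least 3.8-fold lower number from compound 2 to compound 4 (0.58 log units; beyond the scatter), so on this core the change turns a limit into a real number. The same change on the other core, from compound 3 to compound 1, cannot be read, so the compounds shown do not tell whether the gain carries over from one core to the other, and one clear step is no rule for the series. The two steps cannot be set side by side because only compound 4 gives a number and the others stop at a limit: the limit of > 67200 nM in this assay, at which 3 of the 4 values shown sit.

Going by these compounds, it remains open whether the gain needs the free hydroxy group of compound 4, which compound 1 and compound 3 carry as a methoxymethoxy group, or the saturated chain. Also open, on these data alone, is what an amine or a carboxylic acid at the end of the chain would do in this assay.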